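Fluoro to methoxy on the pendant aryl ring: cytotoxicity notes

The source may report more compounds than this note shows. Statements on the series, on what has been measured and on what is new or still open speak of the compounds shown alone.

Measured so far:
compound 1, `O=[N+]([O-])c1ccc(CN2CCC(n3cc(CC(OCc4cc(-c5cccc(F)c5)no4)c4ccc(Br)cc4)nn3)CC2)cc1`, 5000 nM
compound 2, `COc1cccc(-c2cc(COC(Cc3cn(C4CCN(Cc5ccc([N+](=O)[O-])cc5)CC4)nn3)c3ccc(Br)cc3)on2)c1`, 5000 nM
compound 3, `O=[N+]([O-])c1ccc(CN2CCC(n3cc(CC(OCc4cc(-c5ccccc5F)no4)c4ccc(Br)cc4)nn3)CC2)cc1`, 4000 nM

All three numbers come from a functional assay on Caco-2 cells (Homo sapiens) for cytotoxicity, with a stated time of 48 h; a lower number here means a stronger inhibitor, a higher number a weaker inhibitor. The values of compound 1 and compound 2 in this assay sit on top of each other, and compound 3 sits close by: a 1.3-fold lower number from compound 1 to compound 3 (0.10 log units; within the scatter) and a 1.3-fold lower number from compound 2 to compound 3 (0.10 log units; within the scatter). No ordering can be read among them.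

The two cores differ only in where the fluorine sits on the pendant aryl ring, as counted here: 2-fluorophenyl in place of 3-fluorophenyl on an aromatic carbon.

The change from compound 1 to compound 2 is methoxy in place of fluoro on an aromatic carbon. It gave no change at the digits printed from compound 1 to compound 2 (within the scatter).

Compound 4, `COc1ccccc1-c1cc(COC(Cc2cn(C3CCN(Cc4ccc([N+](=O)[O-])cc4)CC3)nn2)c2ccc(Br)cc2)on1`, has not been measured. It is made from compound 3 by methoxy in place of fluoro on an aromatic carbon. This is the same kind of change as that from compound 1 to compound 2, not the same change: in the earlier pair the place is meta to a large group, here it is ortho to a large group.

The expectation for compound 4 rests on compound 1 and compound 2, whose change gave no change at the digits printed from compound 1 to compound 2 (within the scatter). The step from compound 3 to compound 4 in this assay is therefore expected to be a 1.1-fold higher number from compound 3 to compound 4 (0.05 log units; within the scatter), within the scatter. The estimate for compound 4 in this assay is 4500 nM, expected to fall between 2000 nM and 10000 nM. Among the measured compounds shown here, the different place of the change is the main source of doubt; only one earlier pair of this kind exists here.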

Compound 4, half-maximal inhibitory concentration: > 25000 nM
Compound 4: no number, only a limit (the forecaster's own chance of this, stated with the estimate: 15%); middle value at least 5.5-fold (0.74 log units) from the limit.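

In this assay compound 4 gives > 25000 nM, which is a limit of the assay and not a number: the limit of > 25000 nM in this assay, at which 1 of the 4 values shown sits.

Methoxy in place of fluoro does not carry over unchanged from one core to the other: the same change on two cores in this assay, no change at the digits printed (within the scatter) from compound 1 to compound 2 and an at least 6.2-fold higher number (0.79 log units; beyond the scatter) from compound 3 to compound 4, at least 6.2-fold (0.79 log units) apart, beyond the scatter of two such steps

The steps read an at least 6.2-fold higher number from compound 3 to compound 4 (0.79 log units; beyond the scatter), an at least 5.0-fold higher number from compound 2 to compound 4 (0.69 log units; beyond the scatter) and an at least 5.0-fold higher number from compound 1 to compound 4 (0.69 log units; beyond the scatter), so the 2-methoxyphenyl compound stands apart from the other three, but each step is only a floor and each place is covered by a single pair, so the notes show neither the full size of the shift nor whether it belongs to the methoxy group at this place, ortho to a large group, or to some feature of that particular pairing.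

The compounds shown leave open how other groups at the same place would read in this assay, for example an ethoxy group, an amine or a carboxylic acid, and whether a chloro group there would stay with the fluoro compounds or move towards the limit. Also open, as far as these compounds go, is whether the gap between the 2-methoxyphenyl and 3-methoxyphenyl compounds survives when the bromo group of the shared core gives way to another group, such as chloro or nitrile.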